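The compounds below may be only part of what the source reports. "The series", "measured", "known", "first", "only" and "open" are said of these compounds alone.

Compound 1 `CCCC[C@]1(CC)CS(=O)(=O)c2ccc(NO)cc2[C@@H](c2ccccc2)[C@H]1O` is the weakest of the three measured compounds in an assay on cells for inhibition of ileal sodium/bile acid cotransporter (Homo sapiens) (a higher number here means a weaker inhibitor, a lower number a stronger inhibitor), where compound 1 gives 260 nM. Compound 2 `CCCC[C@]1(CC)CS(=O)(=O)c2ccc(SC)cc2[C@@H](c2ccc(F)cc2)[C@H]1O` gives 19 nM and compound 3 `CCCC[C@]1(CC)CS(=O)(=O)c2ccc(C3CCNC3)cc2[C@@H](c2ccc(F)cc2)[C@H]1O` gives 59 nM; both carry a fluorine on the pendant phenyl ring, which compound 1 lacks, so neither is a single-change neighbour of compound 1. Among the measured compounds shown here, the one measured single change is the move from methylsulfanyl to pyrrolidin-3-yl on the aromatic carbon of the shared core, which gave a 3.1-fold higher number from compound 2 to compound 3 (0.49 log units; beyond the scatter): a nitrogen-bearing, basic group in that position cost some potency but left a strong inhibitor.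

Compound 4 `CCCC[C@]1(CC)CS(=O)(=O)c2ccc([N+](C)(C)C)cc2[C@@H](c2ccccc2)[C@H]1O` is obtained from compound 1 by a group of 4 heavy atoms (3 carbon, 1 nitrogen; no ring) in place of a group of 2 heavy atoms (1 nitrogen, 1 oxygen; no ring), on an aromatic carbon; the hydroxyamino group leaves and a permanently charged trimethylammonium group enters. For the measured compounds named here, no measured step exchanges a neutral group for a charged one, so the step from compound 2 to compound 3 is only a loose guide that substituents of differing character at this aromatic carbon are tolerated within a modest range. The expectation for compound 4 is therefore a number close to that of compound 1, with a 2.2-fold lower number from compound 1 to compound 4 (0.34 log units; beyond the scatter) allowed to fall either way. Compound 4 is estimated at 120 nM, with a range from 25 nM to 600 nM.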

Compound 4, half-maximal inhibitory concentration: 83 nM
The estimate for compound 4 lay 1.4-fold (0.16 log units) above the measured number; low and high end bracket the measured number.
By their numbers in this assay, from the lowest: compound 2; then compounds 3 and 4 (each within the scatter of the next); then compound 1.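

In this assay, the step of a 3.1-fold lower number from compound 1 to compound 4 (0.50 log units; beyond the scatter) shows that this aromatic carbon accepts a group with net charge +1 and no hydrogen-bond donors or acceptors, and that the number falls rather than rises when such a group replaces hydroxyamino. The hydrogen-bond donors and acceptors counted on hydroxyamino are therefore not needed for inhibition on this core, and this is the first single change shown on the core with the unsubstituted phenyl ring rather than the fluorinated one. Nothing measured here explains why the number fell, so the step records a result and not a mechanism.

A tert-butyl group or a dimethylamino group at the same aromatic carbon would help show whether the lower number goes with the net charge or with the shape of the group, since the change to compound 4 alters both at once. The effect of a fluorine on the pendant phenyl ring also stays open, as no pair of compounds shown differs in that fluorine alone.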